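The source may report more compounds than this note shows. Statements on the series, on what has been measured and on what is new or still open speak of the compounds shown alone.

Series notes. Compound 3 `Nc1ncnc2c1ncn2CC(O)C(=O)OCc1ccco1` stands lowest of the three numbers in a functional assay on PRK cells (Oryctolagus cuniculus) for cytotoxicity (on this read-out higher numbers stand for lower toxicity in this test and lower numbers for higher toxicity in this test), at 40 ug/mL. Compound 1 `CCCCOC(=O)C(O)Cn1cnc2c(N)ncnc21` gives 200 ug/mL and compound 2 `CCCCCOC(=O)C(O)Cn1cnc2c(N)ncnc21` gives 200 ug/mL; the step of no change at the digits printed from compound 1 to compound 2 (within the scatter) shows that the two alkyl esters sit within the scatter of each other. The steps of a 5.0-fold lower number from compound 1 to compound 3 (0.70 log units; beyond the scatter) and a 5.0-fold lower number from compound 2 to compound 3 (0.70 log units; beyond the scatter) both run toward the lower number when furan-2-yl replaces propyl or butyl. Compound 4 `CC(C)COC(=O)C(O)Cn1cnc2c(N)ncnc21` reverses that kind of change: isopropyl in place of furan-2-yl on a saturated chain carbon bound to an oxygen next to a carbonyl group. Both steps bear on it directly, and since the alkyl esters did not differ among themselves, a step of similar size in the opposite direction is expected, a 5.0-fold higher number from compound 3 to compound 4 (0.70 log units; beyond the scatter). Compound 4 is therefore estimated at 200 ug/mL, with a range from 80 ug/mL to 400 ug/mL.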

Compound 4, minimum cytotoxic concentration: > 400 ug/mL
Compound 4 was reported as a limit; the forecaster's own chance of this, stated with the estimate: 10%; middle value at least 2.0-fold (0.30 log units) from the limit.
By their numbers in this assay, from the lowest: compound 3; then compounds 1 and 2 (each within the scatter of the next). At a limit, above all of these: compound 4.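

In this assay compound 4 is reported only as a limit, > 400 ug/mL. The change from (furan-2-yl)methyl to isobutyl gives an at least 10-fold higher number from compound 3 to compound 4 (1.00 log units; beyond the scatter), so compound 3 now stands apart from three alkyl esters rather than two. Against the straight chains the result reads an at least 2.0-fold higher number from compound 2 to compound 4 (0.30 log units; that floor lies within the scatter) and an at least 2.0-fold higher number from compound 1 to compound 4 (0.30 log units; that floor lies within the scatter); both floors lie within the scatter, so no effect of branching can be read. The compounds shown leave open how far past its limit compound 4 lies, and whether a benzyl or a tetrahydrofuran-2-ylmethyl ester would stand with compound 3 or with the alkyl esters.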